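Swapping the Chlorophenoxy Tail for a Pyrazolyl Ring

A few compounds are considered here, and "the series" means these few. Any claim that something is new, unique, unknown or untested is made for them only; others in the source may bear on it.

Three compounds have been measured in an assay on microsomes from brain (strain Sprague-Dawley) for inhibition of Fatty-acid amide hydrolase 1 (Rattus norvegicus), read by HPLC, with stated times of 10 min and 45 min; a lower number here means a stronger inhibitor, a higher number a weaker inhibitor:
Compound 1, `O=C1C=CC(=O)N1c1ccc(Oc2ccccc2)cc1`, gives 5300 nM.
Compound 2, `CN(C)C(=O)n1nnnc1Cc1ccc(Oc2ccccc2)cc1`, gives 6 nM.
Compound 3, `CN(C)C(=O)n1nnc(-c2ccc(Oc3ccc(Cl)cc3)cc2)n1`, gives 16 nM.

Among these three numbers, compound 3 holds the second highest. Its nearest neighbour is compound 2, whose lower number lies beyond the usual scatter, so compound 2 is the stronger inhibitor of the two. The most distant is compound 1, whose far higher number places it well beyond the scatter as a much weaker inhibitor. For the measured compounds named here, no two of the measured compounds differ in a single place, so no measured step is available to lean on.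

Compound 4, `CN(C)C(=O)n1nnc(-c2ccc(-n3cccn3)cc2)n1`, differs from compound 3 in one spot: 1H-pyrazol-1-yl in place of 4-chlorophenoxy on an aromatic carbon. The group that leaves is larger and carries a chlorine; the group that enters is a small heteroaromatic ring attached directly to the phenyl ring.

Without a comparable measured step, the size of the change can only be guessed. The expectation is a modest rise in the number, probably just beyond the scatter, amounting to a 2.8-fold higher number from compound 3 to compound 4 (0.45 log units; beyond the scatter). On that basis compound 4 is estimated at 45 nM, with a likely range from 12 nM to 200 nM.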

Compound 4, half-maximal inhibitory concentration: 8 nM
Compound 4: middle estimate off by 5.6-fold (0.75 log units), on the high side; measured number below the stated range.
By their numbers in this assay, from the lowest: compounds 2, 4 and 3 (each within the scatter of the next, the first and the last beyond it); then compound 1.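

In this assay, putting 1H-pyrazol-1-yl in place of 4-chlorophenoxy gives a 2.0-fold lower number from compound 3 to compound 4 (0.30 log units; within the scatter), so the two compounds cannot be told apart in this measurement. For the compounds shown here, this is the first direct comparison at this aromatic carbon, para to a large group, and it shows that the position accepts two quite different groups: 4-chlorophenoxy, with 8 heavy atoms and a six-membered ring of carbon only, and 1H-pyrazol-1-yl, with 5 heavy atoms and a five-membered ring holding 2 hetero atoms. Neither the chlorine, the oxygen link nor the six-membered outer ring is therefore needed at this position for a low number, and nothing shown explains how two such different groups give results within the usual scatter of each other.

The compounds shown leave open how far this tolerance extends, since a single exchange cannot show whether a plain hydrogen, a methoxy group, an amine or a carboxylic acid at this position would also keep the number low. From the compounds shown here alone, it also remains open whether 1H-pyrazol-1-yl would give a similar result on the core of compound 2, which differs from compound 4 in more than one place.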